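From a Nitrophenyl to a Benzothiazolyl Amide Substituent

The source may hold more compounds than are shown below. What is called first, only, known or untested is meant among the compounds shown, and "the series" means these compounds.

Three compounds have been measured in an assay on isolated protein for inhibition of histone deacetylase 4 (Homo sapiens), with a stated time of 1 h; on this read-out lower numbers stand for stronger inhibition and higher numbers for weaker inhibition:

compound 1, `COc1cccc(NC(=O)COc2ccc3cc(/C=C4/SC(=O)NC4=O)ccc3c2)c1`: 1600 nM
compound 2, `O=C(COc1ccc2cc(/C=C3/SC(=O)NC3=O)ccc2c1)Nc1ccccn1`: 17000 nM
compound 3, `O=C(COc1ccc2cc(/C=C3/SC(=O)NC3=O)ccc2c1)Nc1ccc([N+](=O)[O-])cc1`: 1700 nM

Compound 3 gives the second highest of the three numbers. Its nearest neighbour is compound 1, with a 1.1-fold higher number from compound 1 to compound 3 (0.03 log units; within the scatter), a difference inside the scatter, so the two cannot be ordered. Compound 2 lies furthest away, with a 10-fold lower number from compound 2 to compound 3 (1.00 log units; beyond the scatter). Between compound 1 and compound 2 the step is an 11-fold higher number from compound 1 to compound 2 (1.03 log units; beyond the scatter).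

Compound 4, `Cc1cccc2sc(NC(=O)COc3ccc4cc(/C=C5/SC(=O)NC5=O)ccc4c3)nc12`, has not yet been measured. It differs from compound 3 by 4-methyl-1,3-benzothiazol-2-yl in place of 4-nitrophenyl on an amide-type nitrogen.

Among the compounds with values here, two measured steps bear on this change, both exchanging one aryl for another on the same amide-type nitrogen. Replacing one six-membered carbon ring by another left the number essentially unchanged, a 1.1-fold higher number from compound 1 to compound 3 (0.03 log units; within the scatter). Replacing a six-membered carbon ring by a six-membered ring holding a nitrogen raised it clearly, a 10-fold lower number from compound 2 to compound 3 (1.00 log units; beyond the scatter) read in reverse. Within the data shown here, the entering group in compound 4 is again a heteroaryl, though bicyclic and with a five-membered ring, so no measured pair matches it closely. A modest rise in this assay is therefore expected for compound 4, with wide uncertainty, a 2.4-fold higher number from compound 3 to compound 4 (0.37 log units; beyond the scatter). Compound 4 is estimated at 4000 nM, within 1000 nM to 20000 nM.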

Compound 4, half-maximal inhibitory concentration: 1200 nM
Compound 4: the middle estimate sits 3.3-fold (0.52 log units) above what was measured, within the range that was stated.
By their numbers in this assay, from the lowest: compounds 4, 1 and 3 (each within the scatter of the next); then compound 2.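

In this assay the 4-methyl-1,3-benzothiazol-2-yl group joins the 4-nitrophenyl and 3-methoxyphenyl groups, with a 1.4-fold lower number from compound 3 to compound 4 (0.15 log units; within the scatter) and a 1.3-fold lower number from compound 1 to compound 4 (0.12 log units; within the scatter) both inside the usual scatter, so these three compounds cannot be ordered. The earlier compounds shown here carried only single six-membered rings on this amide-type nitrogen; compound 4 shows that a two-ring group with a five-membered aromatic ring holding two hetero atoms can stand there without leaving that level, and that a ring nitrogen in the entering group does not by itself go with the weak number of compound 2, as a 14-fold lower number from compound 2 to compound 4 (1.15 log units; beyond the scatter) makes plain. Nothing measured here explains why the pyridin-2-yl compound stands apart from the other three.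

The compounds shown leave open what the methyl group contributes, since they do not tell how a 1,3-benzothiazol-2-yl group without it, or one carrying a chlorine or a methoxy group instead, would read in this assay. They also leave open whether a pyridin-3-yl group or a saturated ring such as piperidinyl on the same nitrogen would fall with compound 2 or with the other three.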